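Extending the hydroxycarbamoyl chain: compound 1 to compound 3

The compounds below may be only part of what the source reports. "The series", "measured", "known", "first", "only" and "open" are said of these compounds alone.

Measured in a functional assay on Hep 3B2 cells (Homo sapiens) for antiproliferative activity, read by sulforhodamine B assay, with a stated time of 48 h; a higher number here means a weaker inhibitor of growth, a lower number a stronger inhibitor of growth:
- compound 1 `CC(C)CCc1c(OCCCCCC(=O)NO)ccc2ccc(=O)oc12`: 800 nM
- compound 2 `CC(C)CCc1c(OCCCCCCC(=O)NO)ccc2c1OC(=O)CC2`: > 30000 nM

Among the compounds with values here, compound 1 gives 800 nM, the only actual number so far. Compound 2 gives > 30000 nM, which is a limit of this assay and not a number.

In compound 3 `CC(C)CCc1c(OCCCCCCCC(=O)NO)ccc2ccc(=O)oc12`, 2-(hydroxycarbamoyl)ethyl stands in place of hydroxycarbamoyl on a saturated chain carbon, five bonds along the chain from an oxygen on an aromatic ring (2-(hydroxycarbamoyl)ethyl in place of hydroxycarbamoyl on a saturated chain carbon, five bonds along the chain from an oxygen on an aromatic ring).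

Within the data shown here, no measured pair yet isolates a single change, so the expectation is only loosely anchored, on compound 1 at 800 nM. A modest move towards stronger growth inhibition, a lower number in this assay, is expected, possibly no larger than the scatter. The expected change is a 1.6-fold lower number from compound 1 to compound 3 (0.20 log units; within the scatter). For compound 3 the estimated value is 500 nM, with an expected range of 100 nM to 3000 nM.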

Compound 3, concentration for 50% growth inhibition: 3580 nM
Compound 3: the middle estimate sits 7.2-fold (0.85 log units) below what was measured; the measured number lies above the stated range.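

In this assay, the first readable single change is 2-(hydroxycarbamoyl)ethyl in place of hydroxycarbamoyl on a saturated chain carbon, five bonds along the chain from an oxygen on an aromatic ring, and it gives a 4.5-fold higher number from compound 1 to compound 3 (0.65 log units; beyond the scatter). With the shared core held constant, this position therefore responds to chain length, and for this pair the longer chain weakens growth inhibition, although one step sets no trend. Compound 2 differs from compound 1 and compound 3 in more than one place, and its reading is a limit and not a number: the limit of > 30000 nM in this assay, at which 1 of the 3 values shown sits.

Still open, on these data alone, is how a shorter chain, or one of intermediate length on the core of compound 1, would read. Also open, as far as these compounds go, is whether a carboxylic acid could stand in place of the hydroxycarbamoyl end.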